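Swapping a hydroxyl for a carboxylic acid on the amide chain

The source may hold more compounds than are shown below. What is called first, only, known or untested is meant among the compounds shown, and "the series" means these compounds.

Compound 1 `CCn1c(C(=O)N[C@H](C)C(=O)OC)ccc1C(CC)(CC)c1ccc(OCS(=O)(=O)c2ccccc2)c(C)c1` gives in a functional assay on BXPC-3 cells (Homo sapiens) for antiproliferative activity, read by MTT assay, with a stated time of 24 h (a lower number here means a stronger inhibitor, a higher number a weaker inhibitor), only a limit, > 50000 nM.
Compound 2 `CCn1c(C(=O)NCCN)ccc1C(CC)(CC)c1ccc(OCS(=O)(=O)c2ccccc2)c(C)c1` gives 6430 nM in this assay.
Compound 3 `CCn1c(C(=O)NCCCO)ccc1C(CC)(CC)c1ccc(OCS(=O)(=O)c2ccccc2)c(C)c1` gives 26600 nM in this assay.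

Compound 3 holds the higher of the two plain numbers: a 4.1-fold higher number from compound 2 to compound 3 (0.62 log units; beyond the scatter). Compound 4 `CCn1c(C(=O)NCCC(=O)O)ccc1C(CC)(CC)c1ccc(OCS(=O)(=O)c2ccccc2)c(C)c1` differs from compound 3 at one spot: carboxy in place of hydroxymethyl on a saturated chain carbon, two bonds along the chain from an amide-type nitrogen. Among the compounds with values here, two measured steps touch this position. The amide chain clearly matters, as a 4.1-fold higher number from compound 2 to compound 3 (0.62 log units; beyond the scatter) shows, while an at least 1.8-fold lower number from compound 1 to compound 3 (0.27 log units; that floor lies within the scatter) starts from the limit of > 50000 nM in this assay, at which 1 of the 3 values shown sits, and says little. Within the data shown here, no measured step contains a carboxy group, so the direction is uncertain; the expectation for compound 4 is a step near the scatter or somewhat higher, a 1.3-fold higher number from compound 3 to compound 4 (0.12 log units; within the scatter). Compound 4 is therefore estimated at 35000 nM, expected between 12000 nM and 100000 nM.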

Compound 4, half-maximal inhibitory concentration: > 50000 nM
Compound 4: only a limit was reported; the forecaster's own chance of this, stated with the estimate: 35%; middle value at least 1.4-fold (0.15 log units) from the limit.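

Compound 4, with its carboxy group, returns only a limit, as compound 1 does: the limit of > 50000 nM in this assay, at which 2 of the 4 values shown sit. Against the hydroxymethyl end, the change shows only an at least 1.8-fold higher number from compound 3 to compound 4 (0.27 log units; that floor lies within the scatter), so the true size stays unsettled, while swapping the amino end for carboxy gives an at least 7.7-fold higher number from compound 2 to compound 4 (0.89 log units; beyond the scatter), the first clear sign that this chain end can cost activity. The step between the two limits cannot be read.

As far as these compounds go, whether a longer chain ending in an amine would lower the number further remains open. So does whether a primary amide at the chain end would behave like the carboxylic acid.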